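A Larger Amide Group on a Weakly Active Shared Core

A few compounds are considered here, and "the series" means these few. Any claim that something is new, unique, unknown or untested is made for them only; others in the source may bear on it.

Compound 1 `Cn1cc(-c2cnc3ccc(N)nc3c2)cn1`: in a functional assay on HeLa cells (Homo sapiens) for antiproliferative activity, read by MTT assay, with a stated time of 48 h (a higher number here means a weaker inhibitor, a lower number a stronger inhibitor), compound 1 gives > 50000 nM, a limit of the assay.
Compound 2 `Cn1cc(-c2cnc3ccnc(N)c3c2)cn1`: compound 2 gives 40800 nM.
Compound 3 `CC(=O)Nc1ccc2ncc(-c3cnn(C)c3)cc2n1`: compound 3 gives > 50000 nM, a limit of the assay.

Compound 3 therefore has no number of its own; it sits at the limit of > 50000 nM in this assay, at which 2 of the 3 values shown sit, and only compound 2 carries a readable value. Among the compounds with values here, the one step between measured compounds, a step that the two limits leave unreadable from compound 1 to compound 3, runs between two limits and its size cannot be read. Compound 4 `COc1ccc(C(=O)Nc2ccc3ncc(-c4cnn(C)c4)cc3n2)cc1` differs from compound 3 by 4-methoxyphenyl in place of methyl on a carbonyl carbon. Within the data shown here, no measured step touches this change, so no direction beyond the scatter is predicted. Compound 4 is expected near 40000 nM, with a range from 8000 nM to 100000 nM, which amounts to an expected step of an at least 1.2-fold lower number from compound 3 to compound 4 (0.09 log units; that floor lies within the scatter). It would not be surprising if compound 4 again sat at the limit of the assay.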

Compound 4, half-maximal inhibitory concentration: 4900 nM
Estimate against measurement, compound 4: 8.2-fold (0.91 log units) above, outside the stated range (below it).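

Within the data shown here, the only earlier step ran between two limits and could not be read, so this is the first change here with a readable effect: 4-methoxyphenyl in place of methyl on a carbonyl carbon gives an at least 10-fold lower number from compound 3 to compound 4 (1.00 log units; beyond the scatter) in this assay. The group on this carbonyl carbon can therefore shift activity in these cells. The step is only a minimum, since compound 3 has a limit rather than a number: the limit of > 50000 nM in this assay, at which 2 of the 4 values shown sit.

The compounds shown cannot separate the contribution of the aromatic ring from that of its methoxy group. On these data alone, how a plain phenyl or a cyclohexyl group would compare at this carbonyl carbon remains open.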